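A few compounds are considered here, and "the series" means these few. Any claim that something is new, unique, unknown or untested is made for them only; others in the source may bear on it.

The measured compounds:
compound 1, `Cc1ccc(-c2cc(C)n(S(=O)(=O)Oc3ccccc3Cl)n2)cc1`, gives 48.5%
compound 2, `CCc1ccc(-c2cc(C)n(S(=O)(=O)Oc3ccccc3)n2)cc1`, gives 48.1%
compound 3, `O=S(=O)(Oc1ccccc1)n1nc(-c2ccccc2)cc1-c1ccccc1`, gives 39.1%

All three were tested in a functional assay on the whole organism for inhibition, with Mus musculus as the target, in the writhing test, with stated times of 3 days and 20 min, at a dose of 30 mg/kg by the oral route; a lower number here means less inhibition, a higher number more inhibition at the dose given (going by the name of the read-out). Compound 2 stands second highest of the three numbers: in this assay compound 2 gives 48.1%, its nearest neighbour is compound 1, whose number is higher by a margin within the scatter, and its furthest neighbour is compound 3, whose number is lower by a margin that also lies within the scatter. On these numbers the three compounds cannot be told apart.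

Compound 4, `Cc1cc(-c2ccco2)nn1S(=O)(=O)Oc1ccccc1`, has not yet been measured in this assay. It differs from compound 2 in one place: furan-2-yl in place of 4-ethylphenyl on an aromatic carbon. Among the measured compounds shown here, no step between measured compounds that differ in one place is available, so the size of the change cannot be anchored. The numbers of compounds 1, 2 and 3 sit close together, and the expectation for compound 4 is a small downward lean rather than a step beyond the scatter. Compound 4 is expected to give 42%, with a range from 28% to 56%. The expected step of a number 6.1 percentage points lower from compound 2 to compound 4 (within the scatter) is estimated to stay within the scatter.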

Compound 4, a percentage reported as inhibition, in the whole organism at one dose (the size of the read-out at that dose, not a potency): 42.5%
For compound 4 the middle estimate is 0.5 percentage points below the measured one; the range from low to high includes it.
By their numbers in this assay, from the lowest: compounds 3, 4, 2 and 1 (each within the scatter of the next).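

In this assay, among the compounds shown here, the change of 4-ethylphenyl to furan-2-yl gives the first step that can be read at this position, a number 5.6 percentage points lower from compound 2 to compound 4 (within the scatter), and the two compounds cannot be told apart. On this aromatic carbon of the five-membered aromatic ring with 2 nitrogen, a five-membered aromatic ring with 1 hetero atom and 5 heavy atoms thus stands in for a six-membered aromatic carbon ring group of 8 heavy atoms with no difference beyond the scatter. No measurement shown bears on the reason for this result.

Going by these compounds, it remains open whether this position would accept a group of another kind, such as an amine or a carboxylic acid, in place of the aromatic ring. On these data alone, whether any change here can produce a step beyond the scatter also remains open.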